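Carbamate alkyl trimming in a lipophilic series

The source may hold more compounds than are shown below. What is called first, only, known or untested is meant among the compounds shown, and "the series" means these compounds.

Compound 1 `CCOC(=O)Nc1cc(C)n(Cc2cc(Cl)ccc2OCc2ccccc2)n1` and compound 2 `COC(=O)Nc1cc(C)n(Cc2cc(Cl)ccc2OCc2ccccc2)n1` share one core; compound 3 `Cc1cc(NC(=O)OC(C)(C)C)nn1Cc1cc(Cl)ccc1OCC(C)C` and the unmeasured compound 4 `Cc1cc(NC(=O)OC(C)C)nn1Cc1cc(Cl)ccc1OCC(C)C` share another, and the difference between the two cores is not broken down here. In a physicochemical assay for lipophilicity, at pH 7.4 (a lower number here means a more polar compound, a higher number a more lipophilic compound), compound 1 gives > 3.7, which is a limit of the assay and not a number. In this assay compound 2 gives > 3.7, also a limit. Compound 3 gives > 3.7 in this assay, again a limit. For the measured compounds named here, the change from compound 1 to compound 2, (hydrogen in place of methyl on a saturated chain carbon bound to an oxygen next to a carbonyl group), gave a step that the two limits leave unreadable from compound 1 to compound 2, since every value so far sits at the limit of > 3.7 in this assay, at which 3 of the 3 values shown sit. The change from compound 3 to compound 4, (hydrogen in place of methyl on a saturated chain carbon bound to an oxygen next to a carbonyl group and two saturated chain carbons), is the same kind of change, with the place now also bound to two saturated chain carbons. Going by the values given here, compound 4 is expected at 3.9, within 3.4 to 4.4, because the limit of > 3.7 in this assay, at which 3 of the 3 values shown sit, shows no measured compound with a readable number. The step expected is a step that the limit leaves unreadable from compound 3 to compound 4, and compound 4 may well return only a limit in this assay once measured.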

Compound 4, distribution coefficient: > 3.7
Compound 4 gave a limit, no number; the forecaster's own chance of this, stated with the estimate: 65%; the middle value lies beyond the limit too.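

In this assay compound 4 gives > 3.7, a limit of the assay and not a number. No step can be read from compound 3 to compound 4, or from compound 1 to compound 2, because every value sits at one limit: the limit of > 3.7 in this assay, at which 4 of the 4 values shown sit.

The compounds shown leave open where any of the four lies beyond that limit, and whether tert-butyl to isopropyl shifts the read-out at all.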